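The compounds below may be only part of what the source reports. "The series", "measured", "known", "first", "only" and "open" are said of these compounds alone.

Working notes on the series. In a functional assay on KB cells (Homo sapiens) for cytotoxicity (on this read-out lower numbers stand for an effect already at smaller amounts and higher numbers for an effect only at larger amounts of compound), compound 1 `Cn1cncc1/C=N/Nc1ccnc2cc(Cl)ccc12` gives 73.8 uM, compound 2 `Clc1ccc2c(N/N=C/c3cccs3)ccnc2c1` gives 10.4 uM and compound 3 `Clc1ccc2c(N/N=C/c3ccc[nH]3)ccnc2c1` gives 4.8 uM. Compound 3 therefore has the lowest number of the three, and its gap to compound 2 lies beyond the scatter.

The next structure is compound 4 `Clc1ccc2c(N/N=C/c3ccco3)ccnc2c1`, with furan-2-yl in place of 1H-pyrrol-2-yl on a carbon with a double bond to nitrogen.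

All three measured steps change this same group. Two of them, a 7.1-fold lower number from compound 1 to compound 2 (0.85 log units; beyond the scatter) and a 15-fold lower number from compound 1 to compound 3 (1.19 log units; beyond the scatter), start from 1-methyl-1H-imidazol-5-yl and bear only loosely on the new change. Going by the values given here, the closest precedent is a 2.2-fold lower number from compound 2 to compound 3 (0.34 log units; beyond the scatter), which ends in the 1H-pyrrol-2-yl group that leaves here. The series holds no measurement of a furan-2-yl compound, so the direction rests on thin evidence.

In this assay, a small move toward a higher number is expected, probably not beyond the scatter. The expected step is a 1.5-fold higher number from compound 3 to compound 4 (0.16 log units; within the scatter). The estimated value for compound 4 is 7 uM, with an expected range from 3 uM to 18 uM.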

Compound 4, concentration for half-maximal effect: 19.9 uM
Beside the measured number, compound 4's estimate is 2.8-fold (0.45 log units) below it; the whole stated range lies below it.
By their numbers in this assay, from the lowest: compound 3; then compounds 2 and 4 (each within the scatter of the next); then compound 1.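

In this assay, the group on the carbon with a double bond to nitrogen still matters when ring size and hetero atom count stay the same: a 4.1-fold higher number from compound 3 to compound 4 (0.62 log units; beyond the scatter) is beyond the scatter, although 1H-pyrrol-2-yl and furan-2-yl are both five-membered aromatic rings with 1 hetero atom, and the computed difference is a hydrogen-bond donor leaving and a hydrogen-bond acceptor entering. Furan-2-yl and thiophen-2-yl cannot be separated on this read-out, as a 1.9-fold higher number from compound 2 to compound 4 (0.28 log units; within the scatter) stays within the scatter, while a 3.7-fold lower number from compound 1 to compound 4 (0.57 log units; beyond the scatter) shows that the gap to the 1-methyl-1H-imidazol-5-yl group of compound 1 remains beyond the scatter for furan-2-yl as well. No measured evidence is available to explain these differences.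

The compounds shown leave open whether the hydrogen on the ring nitrogen of 1H-pyrrol-2-yl is what sets compound 3 apart from compound 4; a 1-methyl-1H-pyrrol-2-yl group at the same place would test this directly. They also leave open how far this position tolerates a substituent on the five-membered ring, such as an amine or a carboxylic acid.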